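Swapping a butyl ester for a furan on the aromatic amine

The source may report more compounds than this note shows. Statements on the series, on what has been measured and on what is new or still open speak of the compounds shown alone.

Measured compounds:
- compound 1 `CC1(C)Oc2ccc(C#N)cc2[C@H](N(CC(=O)O)c2ccccc2)[C@H]1O`: > 100000 nM
- compound 2 `CCCCOC(=O)CN(c1ccccc1)[C@H]1c2cc(C#N)ccc2OC(C)(C)[C@@H]1O`: 27000 nM
- compound 3 `CCOC(=O)C(=O)N(c1ccc(F)cc1)[C@H]1c2cc(C#N)ccc2OC(C)(C)[C@@H]1O`: 43000 nM

All three share one core and differ only in what hangs on the aromatic amine. In a functional assay (aorta) with Rattus norvegicus as the target (a lower number here means a stronger inhibitor, a higher number a weaker inhibitor), compound 1 gives > 100000 nM, which is a limit of the assay and not a number. In this assay compound 2 gives 27000 nM, the lowest of the two actual numbers shown. Compound 3 gives 43000 nM, which sits within the scatter of compound 2, so no order between them can be claimed.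

Compound 4 `CC1(C)Oc2ccc(C#N)cc2[C@H](N(Cc2ccco2)c2ccccc2)[C@H]1O` has not been measured. It differs from compound 2 by furan-2-yl in place of butoxycarbonyl on a saturated chain carbon bound to a nitrogen on an aromatic ring. Among the measured compounds shown here, only one measured step touches this position: an at least 3.7-fold lower number from compound 1 to compound 2 (0.56 log units; beyond the scatter), and that step reaches only the limit noted under (the limit of > 100000 nM in this assay, at which 1 of the 3 values shown sits). It compares an acid with an ester, not an ester with a furan, so it gives little guidance for the present change. For the measured compounds named here, with no closer precedent, compound 4 is expected to stay near compound 2, the estimated step being a 1.1-fold lower number from compound 2 to compound 4 (0.03 log units; within the scatter). Compound 4 is therefore estimated at 25000 nM, within a range of 6000 nM to 100000 nM.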

Compound 4, half-maximal inhibitory concentration: 12000 nM
The estimate for compound 4 lay 2.1-fold (0.32 log units) above the measured number; measured number inside the range.
By their numbers in this assay, from the lowest: compound 4; then compounds 2 and 3 (each within the scatter of the next). At a limit, above all of these: compound 1.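

In this assay, the saturated chain carbon bound to a nitrogen on an aromatic ring turns out not to depend on an ester: furan-2-yl in place of butoxycarbonyl gives a 2.3-fold lower number from compound 2 to compound 4 (0.35 log units; beyond the scatter). Among the compounds shown here, until now, the only step at this place compared an acid with an ester, whereas this one shows that a five-membered aromatic ring with no carbonyl group is accepted here and gives a lower number than the butyl ester. Furan-2-yl in place of carboxy gives an at least 8.3-fold lower number from compound 1 to compound 4 (0.92 log units; beyond the scatter), but compound 1 stands at a limit and not a number, so this step has no upper end: the limit of > 100000 nM in this assay, at which 1 of the 4 values shown sits.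

The compounds shown leave open whether the furan ring itself matters or whether another ring on this chain carbon, such as phenyl or thiophen-2-yl, would do the same. They also leave open how a plain butyl chain or an amine would behave here, and so whether a ring is needed at all.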